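The source may report more compounds than this note shows. Statements on the series, on what has been measured and on what is new or still open speak of the compounds shown alone.

Of the compounds shown here, three have so far been measured in a functional assay on cardiac atrium for agonist activity at histamine H2 receptor (Cavia porcellus); a lower number here means a less potent compound, a higher number a more potent compound, by a factor of ten per unit of this negative logarithm. Compound 1 `Cc1ccc(C(CC/N=C(\N)NCCCc2c[nH]cn2)c2ccccn2)cc1` gives 7.71, compound 2 `N=C(NCCCc1c[nH]cn1)NCCC(c1ccccn1)c1cccs1` gives 7.16, and compound 3 `N=C(NCCCc1c[nH]cn1)NCCC(c1ccc(F)cc1)c1cccnc1` gives 8.09, the highest of the three, standing beyond the scatter above both compound 1 and compound 2. Compound 4 `N=C(NCCCc1c[nH]cn1)NCCC(Cc1ccccc1)c1ccc(F)cc1` has not yet been measured; it differs from compound 3 by benzyl in place of pyridin-3-yl on a saturated chain carbon bound to an aromatic carbon and a saturated chain carbon. Among the compounds with values here, no measured pair shows this particular change, so the expectation rests on compound 3 alone. With the pyridin-3-yl group exchanged for benzyl, a decrease is expected in this assay, estimated as a step of a number 0.89 log units lower from compound 3 to compound 4 (beyond the scatter). Compound 4 is therefore expected to reach about 7.2, within a range from 6.5 to 7.9.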

Compound 4, negative logarithm of the half-maximal effective concentration: 6.17
Estimate against measurement, compound 4: 1.03 log units above, and the stated range ends above it.
By their numbers in this assay, from the lowest: compound 4; then compound 2; then compound 1; then compound 3.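

On a saturated chain carbon bound to an aromatic carbon and a saturated chain carbon, this position proves sensitive in this assay: benzyl in place of pyridin-3-yl gives a number 1.92 log units lower from compound 3 to compound 4 (beyond the scatter) and provides the first single-place comparison among these compounds. The exchange removes the ring nitrogen and adds a carbon together, so this one step cannot assign the loss to either change. Nothing available here explains the drop. Going by these compounds, whether a plain phenyl group or a cyclohexyl group at this place would retain the potency of compound 3 remains open.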